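Changing the ring on the sulfonamide nitrogen

This account rests on a few compounds, and the source may have more. Where it says the series, first, only, none or still open, it means among the compounds named here.

Measured in a functional assay on A2780 cells (Homo sapiens) for antiproliferative activity, read by MTT assay, with a stated time of 72 h; on this read-out lower numbers stand for stronger inhibition of growth and higher numbers for weaker inhibition of growth:
Compound 1 `COc1cc(OC)c(/C=C/S(=O)(=O)Nc2ccc(OC)nc2)c(OC)c1`: 380 nM
Compound 2 `COc1cc(OC)c(/C=C/S(=O)(=O)Nc2ccc(Cl)cc2)c(OC)c1`: > 10000 nM (a limit of the assay, not a number)

Compound 2 sits at the limit of > 10000 nM in this assay, at which 1 of the 2 values shown sits, so only a limit is known for it. Compound 3 `COc1cc(OC)c(/C=C/S(=O)(=O)Nc2cnc(Cl)cn2)c(OC)c1` carries 5-chloropyrazin-2-yl in place of 4-chlorophenyl on a sulfonamide nitrogen. Going by the values given here, one measured step bears on this change: an at least 26-fold higher number from compound 1 to compound 2 (1.42 log units; beyond the scatter), which is large and beyond the scatter. Read in reverse, that step shows a much lower number after 4-chlorophenyl is replaced, though by a different group that has no chlorine. Only part of that gain is therefore expected here, pointing to stronger growth inhibition in this assay. The expected change is an at least 3.3-fold lower number from compound 2 to compound 3 (0.52 log units; beyond the scatter). For compound 3 the estimate is 3000 nM, with an expected range of 700 nM to 10000 nM.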

Compound 3, concentration for 50% growth inhibition: > 10000 nM
Compound 3: a limit, no number; the forecaster's own chance of this, stated with the estimate: 35%; middle value at least 3.3-fold (0.52 log units) away from the limit.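

Compound 3 gives > 10000 nM, a limit of the assay and not a number, and it shares that limit with compound 2: the limit of > 10000 nM in this assay, at which 2 of the 3 values shown sit. The step between these two cannot be read, since both are limits. Replacing 6-methoxypyridin-3-yl with 5-chloropyrazin-2-yl gives an at least 26-fold higher number from compound 1 to compound 3 (1.42 log units; beyond the scatter), so ring nitrogens alone do not bring back the growth inhibition seen with compound 1.

As far as these compounds go, it remains open whether the methoxy group or the ring nitrogen of 6-methoxypyridin-3-yl matters more. A 4-methoxyphenyl or 5-methoxypyrazin-2-yl group on the sulfonamide nitrogen would help separate the two.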